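The source may hold more compounds than are shown below. What is called first, only, known or untested is meant among the compounds shown, and "the series" means these compounds.

Measured so far in a functional assay on MCF7 cells (Homo sapiens) for cytotoxicity, read by MTT assay, with a stated time of 3 days; a higher number here means a weaker inhibitor, a lower number a stronger inhibitor:
Compound 1 `COc1ccc(-c2ccccc2)cc1`: > 100 ug/mL, a limit of the assay
Compound 2 `COc1ccc(-c2ccccc2)cc1OC`: 45 ug/mL
Compound 3 `COc1ccc(-c2cccc(N)c2)cc1OC`: > 100 ug/mL, a limit of the assay

Compound 2 alone carries a true number, while the other two sit at the limit of > 100 ug/mL in this assay, at which 2 of the 3 values shown sit. Compound 4 `COc1ccc(-c2ccc(N)cc2)cc1OC` differs from compound 2 as follows: amino in place of hydrogen on an aromatic carbon. The new amino group stands para to a large group. The methoxy change, an at least 2.2-fold lower number from compound 1 to compound 2 (0.34 log units; beyond the scatter), bears only on how compound 2 arose from compound 1. The closer guide is compound 3, which has an amino group at a different place and shows an at least 2.2-fold higher number from compound 2 to compound 3 (0.34 log units; beyond the scatter). A similar rise, at least modest, is therefore expected in this assay. The expected change is a 2.2-fold higher number from compound 2 to compound 4 (0.35 log units; beyond the scatter). For compound 4 the estimate is 100 ug/mL, with an expected range from 40 ug/mL to 250 ug/mL.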

Compound 4, half-maximal inhibitory concentration: 5.5 ug/mL
Compound 4: middle estimate off by 18-fold (1.26 log units), on the high side, and the stated range ends above it.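

In this assay, amino in place of hydrogen, para to a large group, gives an 8.2-fold lower number from compound 2 to compound 4 (0.91 log units; beyond the scatter), so this change does not act alike at every place on the ring. Compound 3, with its amino group at a different place, stands at > 100 ug/mL, which is a limit of the assay, so its distance from compound 4 cannot be read: the limit of > 100 ug/mL in this assay, at which 2 of the 4 values shown sit.

Still open, from the compounds shown here alone, is whether a hydroxyl, a dimethylamino group or a carboxylic acid at this place would follow the amino group, and whether the amino gain holds on the core of compound 1.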